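From Amino Linker to Direct Aryl Carbonyl

The source may report more compounds than this note shows. Statements on the series, on what has been measured and on what is new or still open speak of the compounds shown alone.

Compound 3 `COc1cc(Cl)cc(-c2nn(-c3cccc(NC(=O)Nc4cccc(C(F)(F)F)c4)c3)cc2-c2ccncc2)c1` gives 102% in a functional assay on CAKI-1 cells (Homo sapiens) for inhibition, read by sulforhodamine B assay, with a stated time of 48 h, tested at 0.01 uM; a lower number here means a stronger effect, a higher number a weaker effect of the compound at the concentration tested. Compound 1 `COc1cc(Cl)cc(-c2nn(-c3cccc(NC(=O)Nc4ccc(Cl)c(C(F)(F)F)c4)c3)cc2-c2ccncc2)c1` gives 98% and compound 2 `COc1cc(Cl)cc(-c2nn(-c3cccc(NC(=O)Nc4ccc(Cl)c(Cl)c4)c3)cc2-c2ccncc2)c1` gives 96%. The steps of a number 4 percentage points higher from compound 1 to compound 3 (within the scatter) and a number 6 percentage points higher from compound 2 to compound 3 (within the scatter) both lie within the scatter, so the three read alike. Compound 4 `COc1cc(Cl)cc(-c2nn(-c3cccc(NC(=O)c4cccc(C(F)(F)F)c4)c3)cc2-c2ccncc2)c1` is not yet measured. It differs from compound 3 by 3-(trifluoromethyl)phenyl in place of (3-(trifluoromethyl)phenyl)amino on a carbonyl carbon. Going by the values given here, none of the measured steps, a number 2 percentage points lower from compound 1 to compound 2 (within the scatter) included, touches the carbonyl carbon or the amide-type nitrogen; each only varies the substituents of the outer phenyl ring, and each stayed within the scatter. No step beyond the scatter is therefore expected in this assay, the estimated step being a number 3 percentage points lower from compound 3 to compound 4 (within the scatter). Compound 4 is expected to give 99%, between 88% and 110%.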

Compound 4, a percentage reported as activity, at one concentration (the size of the read-out at that concentration, not a potency): 95%
The estimate for compound 4 lay 4 percentage points above the measured number, and the stated range covers the measured number.
By their numbers in this assay, from the lowest: compounds 4, 2, 1 and 3 (each within the scatter of the next).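

Unlike the earlier steps, this one alters the link itself: the carbonyl carbon now carries the 3-(trifluoromethyl)phenyl directly, and the amide-type nitrogen with its hydrogen-bond donor is gone. In this assay, the outcome is a number 7 percentage points lower from compound 3 to compound 4 (within the scatter), alongside a number 1 percentage points lower from compound 2 to compound 4 (within the scatter) and a number 3 percentage points lower from compound 1 to compound 4 (within the scatter), so this nitrogen makes no readable difference at the concentration tested. Nothing at hand offers an explanation for this result. From the compounds shown here alone, whether that holds at other concentrations stays open. So does the effect of a sulfonyl group in place of the carbonyl.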